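Urea series: acetyl in place of isopropyl on the aryl ring

The source may report more compounds than this note shows. Statements on the series, on what has been measured and on what is new or still open speak of the compounds shown alone.

Compound 2 `CC(C)c1ccc(NC(=O)N[C@@H](C)c2ccccc2)cc1` gives 98% in an ADME assay on the whole organism with Oryza sativa as the target, tested at 0.1 uM; on this read-out higher numbers stand for a weaker effect at the one concentration tested and lower numbers for a stronger effect. Compound 1 `CC(C)c1ccc(NC(=O)N[C@H](C)c2ccccc2)cc1` gives 99% and compound 3 `COc1cccc(NC(=O)N[C@H](C)c2ccccc2)c1` gives 104% in this assay; all three numbers sit within the scatter of one another. Going by the values given here, the only step between measured compounds, a number 1 percentage points lower from compound 1 to compound 2 (within the scatter), rests on the fact that compounds 1 and 2 differ only in the configuration as drawn and leaves the group on the aromatic carbon para to a large group untouched. Compound 4 `CC(=O)c1ccc(NC(=O)N[C@@H](C)c2ccccc2)cc1` differs from compound 2 by acetyl in place of isopropyl on an aromatic carbon. Among the compounds with values here, no measured step alters this group, so the three numbers give no direction for it; since the measured values lie close together, compound 4 is expected to remain near them, with a number 1 percentage points lower from compound 2 to compound 4 (within the scatter). The estimate for compound 4 in this assay is 97%, ranging from 82% to 106%.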

Compound 4, a percentage reported as activity, at one concentration (the size of the read-out at that concentration, not a potency): 99%
For compound 4 the middle estimate is 2 percentage points below the measured one; the measured number falls inside the stated range.
By their numbers in this assay, from the lowest: compounds 2, 1, 4 and 3 (each within the scatter of the next).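

In this assay, the step at this position is a number 1 percentage points higher from compound 2 to compound 4 (within the scatter) at the one concentration tested. The swap adds a hydrogen-bond acceptor on an aromatic carbon para to a large group, yet this change does not separate the two compounds. Nothing at hand gives a reason for this result.

Still open, from the compounds shown here alone, is whether an amine, a carboxylic acid or a longer chain at this position would give a step beyond the scatter. Also open, going by these compounds, is whether acetyl gives a similar number on the core of compound 1.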